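Opening the series: cytotoxicity on fibroblasts before compound 4

A few compounds are considered here, and "the series" means these few. Any claim that something is new, unique, unknown or untested is made for them only; others in the source may bear on it.

Measured so far:
- compound 1 `CN(C)CCn1cnnc1-c1cc(Oc2ccc(NC(=O)N/N=C/c3cccc(O)c3)cc2F)ccn1` — "not determined" (no result reported)
- compound 2 `CN(C)CCn1cnnc1-c1cc(Oc2ccc(NC(=O)N/N=C/c3ccc(O)c(F)c3)cc2F)ccn1` — "not determined" (no result reported)
- compound 3 `CN(C)CCn1cnnc1-c1cc(Oc2ccc(NC(=O)N/N=C/c3c(Cl)cccc3Cl)cc2F)ccn1` — 3320 nM

Three compounds share one core and differ only in the aryl group attached to the carbon with a double bond to nitrogen. For compound 1 no number exists in an ADME assay on WI-38 cells (Homo sapiens) for cytotoxicity, read by MTT assay, with a stated time of 72 h; on this read-out lower numbers stand for stronger inhibition and higher numbers for weaker inhibition; its entry reads "not determined" (no result reported). Compound 2 is in the same position, with "not determined" (no result reported) in this assay. The single number in the set belongs to compound 3, which in this assay gives 3320 nM, so compound 1 cannot be ranked against anything on the numbers shown.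

Compound 4 `CN(C)CCn1cnnc1-c1cc(Oc2ccc(NC(=O)N/N=C/c3ccc(F)cc3F)cc2F)ccn1` is the next member, and it differs from compound 1 by 2,4-difluorophenyl in place of 3-hydroxyphenyl on a carbon with a double bond to nitrogen. Among the compounds with values here, no measured pair lets the size of this change be read off in this assay. Within the data shown here, since compound 1 has no number, the only anchor is compound 3, and a step of modest size in either direction, or none beyond the scatter, is the expectation for compound 4 relative to that anchor.

Compound 4 is therefore expected to give 4000 nM in this assay, within a range from 1500 nM to 12000 nM.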

Compound 4, half-maximal inhibitory concentration: 5030 nM
Estimate against measurement, compound 4: 1.3-fold (0.10 log units) below; the measured number falls inside the stated range.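

In this assay, the exchange of 2,6-dichlorophenyl for 2,4-difluorophenyl on a carbon with a double bond to nitrogen gives a 1.5-fold higher number from compound 3 to compound 4 (0.18 log units; within the scatter), so these two groups cannot be told apart on this read-out. Within the data shown here, this is the first pair at this position that can be read at all, and it shows that replacing chlorine substituents with fluorine substituents, at a different arrangement on the phenyl ring, leaves the cytotoxicity on these fibroblasts within the scatter for these two compounds alone. Nothing among the data shown offers an explanation for this result.

Going by these compounds, compound 1 and compound 2 have no number in this assay, so the step from 3-hydroxyphenyl to 2,4-difluorophenyl cannot be read, and whether a hydroxyl group on the phenyl ring shifts the value at all stays unknown. On these data alone, it also remains open whether an aryl group carrying an amine or a carboxylic acid, or an unsubstituted phenyl, would stay close to compound 3 and compound 4 at this place.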